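Amide substituent series: shift from aminoethyl to hydroxymethylethyl

The source may hold more compounds than are shown below. What is called first, only, known or untested is meant among the compounds shown, and "the series" means these compounds.

Compound 1 `CCn1c(C(=O)NCCN)ccc1C(CC)(CC)c1ccc(OCCC(O)(CC)CC)c(C)c1` carries a 2-aminoethyl group on the amide-type nitrogen and is the reference of the set. In a functional assay on MCF7 cells (Homo sapiens) for antiproliferative activity, read by MTT assay, with a stated time of 48 h (on this read-out higher numbers stand for weaker inhibition and lower numbers for stronger inhibition), compound 1 gives 670 nM, the lowest of the two numbers obtained; the nearest measured neighbour sits well apart. Compound 2 `CCn1c(C(=O)Nc2ccc(OC(F)(F)F)cc2)ccc1C(CC)(CC)c1ccc(OCCC(O)(CC)CC)c(C)c1`, with 4-(trifluoromethoxy)phenyl in that position, reaches only the assay limit, > 50000 nM, so no number is known for it. Compound 3 `CCn1c(C(=O)NC(CO)CCO)ccc1C(CC)(CC)c1ccc(OCCC(O)(CC)CC)c(C)c1`, bearing 3-hydroxy-1-(hydroxymethyl)propyl, gives 31400 nM. The step of a 47-fold higher number from compound 1 to compound 3 (1.67 log units; beyond the scatter) is large, and an at least 74-fold higher number from compound 1 to compound 2 (1.87 log units; beyond the scatter) is larger still, while an at least 1.5-fold lower number from compound 2 to compound 3 (0.20 log units; that floor lies within the scatter) says little because one end is a limit (the limit of > 50000 nM in this assay, at which 1 of the 3 values shown sits).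

Compound 4 `CCn1c(C(=O)NC(C)CO)ccc1C(CC)(CC)c1ccc(OCCC(O)(CC)CC)c(C)c1` differs from compound 1 as follows: 1-(hydroxymethyl)ethyl in place of 2-aminoethyl on an amide-type nitrogen. The two measured steps from compound 1 both bear on this: each exchanges the 2-aminoethyl group for a group without the amine, and each cost a large amount of activity. Compound 4 makes the same kind of exchange, with a shorter group than in compound 3, so a large rise in this assay is expected, though perhaps not the full extent seen for compound 3.

Compound 4 is therefore estimated at 8000 nM, within 2000 nM to 40000 nM, meaning an expected step of a 12-fold higher number from compound 1 to compound 4 (1.08 log units; beyond the scatter).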

Compound 4, half-maximal inhibitory concentration: 12600 nM
Compound 4: middle estimate off by 1.6-fold (0.20 log units), on the low side; the range from low to high includes it.
By their numbers in this assay, from the lowest: compound 1; then compound 4; then compound 3. At a limit, above all of these: compound 2.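

In this assay, the exchange of 2-aminoethyl for 1-(hydroxymethyl)ethyl gives a 19-fold higher number from compound 1 to compound 4 (1.27 log units; beyond the scatter), although the counts of hydrogen-bond donors and acceptors stay the same and neither group carries a net charge, so matching those counts does not preserve the value of compound 1 at this amide-type nitrogen. Among the groups without the amine, the position still discriminates, as removal of one hydroxymethyl gives a 2.5-fold lower number from compound 3 to compound 4 (0.40 log units; beyond the scatter), a modest step beside the large one from the 2-aminoethyl reference. The 4-(trifluoromethoxy)phenyl end of the series gives only a floor, an at least 3.9-fold lower number from compound 2 to compound 4 (0.59 log units; beyond the scatter), since that end is a limit and not a number: the limit of > 50000 nM in this assay, at which 1 of the 4 values shown sits.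

The compounds shown do not separate the contribution of the terminal amine from that of the unbranched chain, since 1-(hydroxymethyl)ethyl differs from 2-aminoethyl in both. A 2-hydroxyethyl group would isolate the exchange of amine for hydroxyl, while a 3-aminopropyl or 2-(dimethylamino)ethyl group would show how far chain length and substitution on the amine can vary at this amide-type nitrogen.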